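Two Cores, One Chain Shortening, Cytotoxicity at the Limit

The source may hold more compounds than are shown below. What is called first, only, known or untested is meant among the compounds shown, and "the series" means these compounds.

Of the compounds shown here, three have been tested in an ADME assay on HEL cells (Homo sapiens) for cytotoxicity, read by microscopy, with a stated time of 6 days (a lower number here means that less compound is tolerated, a higher number that more compound is tolerated), and a fourth awaits measurement. Compound 1 `CCCCCCNc1cnc(C(=O)NCc2ccccc2)cn1` carries a hexyl chain on the ring nitrogen; in this assay compound 1 gives a value of > 100000 nM, which is a limit of the assay and not a number. Compound 2 `CCCCNc1cnc(C(=O)NCc2ccccc2)cn1` differs from compound 1 by hydrogen in place of ethyl on a saturated chain carbon, four bonds along the chain from a nitrogen on an aromatic ring; in this assay compound 2 gives > 100000 nM, again a limit rather than a number. The step that the two limits leave unreadable from compound 1 to compound 2 therefore cannot be sized, because the limit of > 100000 nM in this assay, at which 3 of the 3 values shown sit, holds for both of its endpoints. Compound 3 `CCCCCCNc1cncc(C(=O)NCc2ccccc2)n1` has the same atoms as compound 1 joined differently; how the two cores differ is not broken down here. In this assay compound 3 gives > 100000 nM, which is a limit and not a number.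

Compound 4 `CCCCNc1cncc(C(=O)NCc2ccccc2)n1` is related to compound 3 by the same change that turns compound 1 into compound 2, namely (hydrogen in place of ethyl on a saturated chain carbon, four bonds along the chain from a nitrogen on an aromatic ring). Because the limit of > 100000 nM in this assay, at which 3 of the 3 values shown sit, places every measured value at the assay limit, and because a step that the two limits leave unreadable from compound 1 to compound 2 gave no readable movement for this change, compound 4 is expected to remain at that limit too, with an expected step of a number no higher from compound 3 to compound 4 (the limit leaves the size open). Compound 4 is accordingly estimated at 100000 nM in this assay, within an expected range of 50000 nM to 200000 nM.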

Compound 4, minimum cytotoxic concentration: > 100000 nM
Compound 4 gave a limit, no number (the forecaster's own chance of this, stated with the estimate: 85%); the middle value lies on the limit itself.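

The step from compound 3 to compound 4 cannot be read, and neither can any other comparison among the four compounds, because each value is a limit and not a number: the limit of > 100000 nM in this assay, at which 4 of the 4 values shown sit. The compounds shown leave open how far any of the four lies from that limit, and so whether hydrogen in place of ethyl, on either core, moves the result in this assay at all.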